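Three Bromocoumarin Thiazoles and an Unmeasured Debrominated Analogue

The source may hold more compounds than are shown below. What is called first, only, known or untested is meant among the compounds shown, and "the series" means these compounds.

The series rests on three measured compounds. Compound 1 `O=c1cc(CNc2nc(-c3cc4cc(Br)cc(Br)c4oc3=O)cs2)c2cc(Cl)ccc2[nH]1` carries a chloro-substituted core joined through a methylene and an amino link to the thiazole that bears the dibromocoumarin. In a functional assay on the whole organism for inhibition, with Rattus norvegicus as the target, read by paw edema, in the formalin test, at a dose of 100 mg/kg by the intraperitoneal route (on this read-out higher numbers stand for more inhibition at the one dose given (going by the name of the read-out) and lower numbers for less inhibition), compound 1 gives 2.85%. Compound 3 `Cc1cccc2c(CNc3nc(-c4cc5cc(Br)cc(Br)c5oc4=O)cs3)cc(=O)[nH]c12` keeps the same dibromocoumarin but has a methyl-substituted core; the difference between the two cores is not broken down here. In this assay compound 3 gives 2.65%. Compound 2 `Cc1cccc2c(CNc3nc(-c4cc5cc(Br)ccc5oc4=O)cs3)cc(=O)[nH]c12` is the monobrominated partner of compound 3, and in this assay compound 2 gives 1.6%. The three numbers all lie within the usual scatter of one another, so no order among them can be read.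

One structural change has been measured once within the set: hydrogen in place of bromo on an aromatic carbon, which gave a number 1.1 percentage points lower from compound 3 to compound 2 (within the scatter). Compound 4 `O=c1cc(CNc2nc(-c3cc4cc(Br)ccc4oc3=O)cs2)c2cc(Cl)ccc2[nH]1` is the still unmeasured compound that applies the same change to compound 1, namely (hydrogen in place of bromo on an aromatic carbon).

Among the measured compounds shown here, because the only measured instance of this change, a number 1.1 percentage points lower from compound 3 to compound 2 (within the scatter), stayed within the scatter, the step from compound 1 to compound 4 is expected to be a number 0.9 percentage points lower from compound 1 to compound 4 (within the scatter). On that basis the value of compound 4 in this assay is estimated at 2%, with a likely range from -5% to 9%.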

Compound 4, a percentage reported as inhibition, in the whole organism at one dose (the size of the read-out at that dose, not a potency): 3.03%
Compound 4: middle estimate off by 1 percentage points, on the low side; measured number inside the range.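

In this assay, hydrogen in place of bromo on the core of compound 1 gave a number 0.2 percentage points higher from compound 1 to compound 4 (within the scatter). Set beside the earlier case of the same change, the two cores cannot be told apart: the same change on two cores in this assay, a number 1.1 percentage points lower (within the scatter) from compound 3 to compound 2 and a number 0.2 percentage points higher (within the scatter) from compound 1 to compound 4, 1.2 percentage points apart, within the scatter of two such steps This shows that the change stayed within the scatter on both cores and that the choice of core made no readable difference to it, but with only two pairs it fixes neither a size nor a direction for the change on either core, and it says nothing about whether the same would hold on any further core.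

All four compounds keep at least one bromo on the coumarin and the same methylene and amino link to the thiazole, which leaves open how the read-out would respond to an amine or a carboxylic acid in place of that remaining bromo, or to a longer chain in place of the methylene. The chloro and methyl cores also stand only as they are shown, and the read-out at the one dose given leaves open what a hydroxy or methoxy group on these cores would do.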